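The source may report more compounds than this note shows. Statements on the series, on what has been measured and on what is new or still open speak of the compounds shown alone.

Among the compounds with values here, compound 2 `COC(=O)/C=C/c1cccc(N(Cc2ccc(/C=C/c3ccc(OC)cc3)cc2)C(=O)C2CCCCC2)c1` is one of two compounds measured so far in an assay on isolated protein with Bile acid receptor (Homo sapiens) as the target; on this read-out lower numbers stand for an effect already at smaller amounts and higher numbers for an effect only at larger amounts of compound; compound 2 gives 208 nM. Within the data shown here, the other, compound 1 `COC(=O)/C=C/c1cccc(N(Cc2ccc(/C=C/c3scnc3C)cc2)C(=O)C2CCCCC2)c1`, gives 227 nM, and the only known step, a 1.1-fold lower number from compound 1 to compound 2 (0.04 log units; within the scatter), leaves the two within the scatter of each other, so neither stands apart.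

Compound 3 `COC(=O)/C=C/c1cccc(N(Cc2ccc(/C=C/C(=O)O)cc2)C(=O)C2CCCCC2)c1` has not been measured. It differs from compound 2 by carboxy in place of 4-methoxyphenyl on a double-bonded chain carbon bound to a double-bonded chain carbon. Of the measured steps only a 1.1-fold lower number from compound 1 to compound 2 (0.04 log units; within the scatter) touches this position, and it exchanged one aromatic ring for another without moving the number beyond the scatter. Among the measured compounds shown here, no measured step removes the ring at this position altogether or introduces a carboxy group, so the size of the coming step has no direct anchor. The expectation rests on the observation that, because a 1.1-fold lower number from compound 1 to compound 2 (0.04 log units; within the scatter) stayed within the scatter, changes at this position have so far left the number where it was; the present change is larger, and a moderate rise in the number, a 2.9-fold higher number from compound 2 to compound 3 (0.46 log units; beyond the scatter), is expected. Compound 3 is therefore estimated at 600 nM, with a range from 150 nM to 3000 nM.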

Compound 3, half-maximal effective concentration: > 1000 nM
Compound 3: a limit, no number; the forecaster's own chance of this, stated with the estimate: 10%; middle value at least 1.6-fold (0.22 log units) from the limit.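

In this assay, within the data shown here, compound 3 gives > 1000 nM, which is a limit of the assay and not a number, the only such reading so far: the limit of > 1000 nM in this assay, at which 1 of the 3 values shown sits.

This position is not indifferent to every change: the exchange of one aromatic ring for another stayed within the scatter, whereas replacing either ring with carboxy moves the read-out beyond it, with an at least 4.8-fold higher number from compound 2 to compound 3 (0.68 log units; beyond the scatter) and an at least 4.4-fold higher number from compound 1 to compound 3 (0.64 log units; beyond the scatter). Going by these compounds, both steps are lower bounds, so their full size remains unknown, but they show that the two aromatic rings tested at this place are not interchangeable with carboxy in this assay.

The change removes an aromatic ring and introduces carboxy at once, so the compounds shown do not separate the contribution of the departing ring from that of the entering group. Also open, on these data alone, is how a primary amide, a short alkyl chain or a phenyl ring bearing a carboxylic acid would read on the same double-bonded chain carbon, and only such compounds could show which part of the change matters.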